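This account rests on a few compounds, and the source may have more. Where it says the series, first, only, none or still open, it means among the compounds named here.

Compound 2, `Nc1nn(C(=O)Nc2ccc(Cc3ccccc3)cc2)c2ccc(Cl)cc12`, is one of two close analogues measured so far. In a functional assay on SF-295 cells (Homo sapiens) for antiproliferative activity, read by sulforhodamine B assay, with a stated time of 48 h (a lower number here means that less compound is tolerated, a higher number that more compound is tolerated), compound 2 gives only a limit, > 100000 nM. Compound 1, `Nc1nn(C(=O)Nc2ccc(Cc3ccccc3)cc2)c2ccccc12`, likewise gives only a limit in this assay, > 100000 nM. The step that the two limits leave unreadable from compound 1 to compound 2 therefore cannot be read, because both values sit at the limit of > 100000 nM in this assay, at which 2 of the 2 values shown sit. Compound 3, `Nc1ccc2c(c1)c(N)nn2C(=O)Nc1ccc(Cc2ccccc2)cc1`, differs from compound 2 by amino in place of chloro on an aromatic carbon. Within the data shown here, no measured step shows what such an exchange does in this assay, so the only guide is that compound 1 and compound 2 both reach the limit without a number. The expected step of a number no higher from compound 2 to compound 3 (the limit leaves the size open) is therefore none beyond the scatter. For compound 3 the estimate in this assay is 100000 nM, with a range from 30000 nM to 300000 nM, and it is expected that most likely again only a limit is reported.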

Compound 3, concentration lethal to 50% of the cells: 45400 nM
The estimate for compound 3 lay 2.2-fold (0.34 log units) above the measured number; measured number inside the range.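

In this assay, this aromatic carbon proves able to change the read-out: amino in place of chloro gives an at least 2.2-fold lower number from compound 2 to compound 3 (0.34 log units; beyond the scatter), and amino in place of hydrogen gives an at least 2.2-fold lower number from compound 1 to compound 3 (0.34 log units; beyond the scatter). The earlier pair could not show this, since the step between compound 1 and compound 2 cannot be read, so compound 3 is the first of these compounds to give a real number rather than a limit. Both new steps give only a minimum size, not an exact one, because compound 1 and compound 2 have no exact value: the limit of > 100000 nM in this assay, at which 2 of the 3 values shown sit.

The compounds shown leave open whether this drop is specific to amino or whether a hydroxyl, a methoxy or an acetylated amine on the same carbon would also lower the number. They also leave open whether amino would have the same effect on another carbon of this ring.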